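Swapping a Difluorophenyl Amide for an Ethylphenyl Amide

The source may hold more compounds than are shown below. What is called first, only, known or untested is meant among the compounds shown, and "the series" means these compounds.

Three amides share one core and differ only in the aromatic ring attached to the carbonyl carbon. Compound 1 `Cc1ccc(C(=O)Nc2cccc(-c3oc4cc(-c5ccc(F)cc5)ccc4c(=O)c3O)c2)cc1` carries a 4-methylphenyl group there, and in a functional assay on MDA-MB-231 cells (Homo sapiens) for antiproliferative activity, read by CCK-8 assay, with a stated time of 72 h (on this read-out higher numbers stand for weaker inhibition and lower numbers for stronger inhibition), compound 1 gives 4350 nM. Compound 2 `O=C(Nc1cccc(-c2oc3cc(-c4ccc(F)cc4)ccc3c(=O)c2O)c1)c1ccc(F)cc1F` carries a 2,4-difluorophenyl group; in this assay compound 2 gives 11200 nM, the highest of the three numbers and thus the weakest inhibitor among them. Compound 3 `O=C(Nc1cccc(-c2oc3cc(-c4ccc(F)cc4)ccc3c(=O)c2O)c1)c1cccc(F)c1` carries a 3-fluorophenyl group, and in this assay compound 3 gives 2510 nM. Going from compound 1 to compound 2 produced a 2.6-fold higher number from compound 1 to compound 2 (0.41 log units; beyond the scatter), while going from compound 2 to compound 3 produced a 4.5-fold lower number from compound 2 to compound 3 (0.65 log units; beyond the scatter); the direct comparison of the two single-substituted rings, from compound 1 to compound 3, was a 1.7-fold lower number from compound 1 to compound 3 (0.24 log units; within the scatter).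

Compound 4 `CCc1ccc(C(=O)Nc2cccc(-c3oc4cc(-c5ccc(F)cc5)ccc4c(=O)c3O)c2)cc1` has not yet been measured. Its change relative to compound 2 is 4-ethylphenyl in place of 2,4-difluorophenyl on a carbonyl carbon. The nearest measured comparison is compound 1, whose 4-methylphenyl ring likewise carries a single carbon substituent, and leaving the difluorophenyl ring has so far meant a lower number in both measured steps. In this assay compound 4 is therefore expected to give 4000 nM, with a likely range from 1500 nM to 11000 nM. The expected step of a 2.8-fold lower number from compound 2 to compound 4 (0.45 log units; beyond the scatter) is modest, because a 2.6-fold higher number from compound 1 to compound 2 (0.41 log units; beyond the scatter) ran in the opposite direction for a closely related ring.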

Compound 4, half-maximal inhibitory concentration: 9070 nM
The estimate for compound 4 lay 2.3-fold (0.36 log units) below the measured number; low and high end bracket the measured number.
By their numbers in this assay, from the lowest: compounds 3 and 1 (each within the scatter of the next); then compounds 4 and 2 (each within the scatter of the next).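

Going by these compounds alone, on the ring attached to the carbonyl carbon, the 2,4-difluorophenyl and 4-ethylphenyl groups cannot be told apart in this assay (a 1.2-fold lower number from compound 2 to compound 4 (0.09 log units; within the scatter)), so leaving the difluorophenyl ring does not by itself lower the number, as the earlier steps from that ring had suggested. A single added methyl, turning the 4-methylphenyl ring into the 4-ethylphenyl ring, is enough to pass the usual scatter (a 2.1-fold higher number from compound 1 to compound 4 (0.32 log units; beyond the scatter)), and the 4-ethylphenyl ring also stands clearly apart from the 3-fluorophenyl ring (a 3.6-fold higher number from compound 3 to compound 4 (0.56 log units; beyond the scatter)), which shows that this position responds to a small change in the ring's carbon substituent, though only modestly. No supporting measurement is available that would explain these differences.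

Within the data shown here, with only one step from methyl to ethyl, it remains open whether a longer chain such as propyl would raise the number further or whether the effect stops at ethyl. From the compounds shown here alone, it also remains open how this position would respond to a ring carrying an amine or a carboxylic acid in place of the carbon and fluorine substituents compared so far.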